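Swapping the aryl group on the shared core

The compounds below may be only part of what the source reports. "The series", "measured", "known", "first", "only" and "open" are said of these compounds alone.

Compound 2 `Cc1noc(C)c1-c1sc(N)c(C(=O)c2ccc(Cl)cc2)c1CC(C)(C)C` gives 1% in an assay on CHO cells for displacement of a labelled ligand from adenosine receptor A3 (Homo sapiens), read by scintillation counting, tested at 10 uM (a lower number here means less inhibition, a higher number more inhibition at the concentration tested (going by the name of the read-out)), the lowest of the two numbers shown, within the scatter of compound 1 `CC(C)(C)Cc1c(-c2ccc(F)cc2)sc(N)c1C(=O)c1ccc(Cl)cc1`, which gives 9%. Compound 3 `CC(C)(C)Cc1c(-c2ccsc2)sc(N)c1C(=O)c1ccc(Cl)cc1` carries thiophen-3-yl in place of 3,5-dimethyl-1,2-oxazol-4-yl on an aromatic carbon. Going by the values given here, the only step that bears on this is a number 8 percentage points lower from compound 1 to compound 2 (within the scatter), a replacement at the same aromatic carbon that left the read-out within the scatter. A similar replacement is therefore expected to move the number by no more than the scatter, in no clear direction: a number 4 percentage points higher from compound 2 to compound 3 (within the scatter). Compound 3 is estimated at 5%, with a range from -10% to 20%.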

Compound 3, a percentage reported as inhibition, at one concentration (the size of the read-out at that concentration, not a potency): 4%
Beside the measured number, compound 3's estimate is 1 percentage points above it; the measured number falls inside the stated range.
By their numbers in this assay, from the lowest: compounds 2, 3 and 1 (each within the scatter of the next).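

Thiophen-3-yl on this aromatic carbon, next to the ring sulfur, gives a number 3 percentage points higher from compound 2 to compound 3 (within the scatter) and a number 5 percentage points lower from compound 1 to compound 3 (within the scatter). Three different ring groups at this place, including a sulfur-containing ring, now give numbers within the scatter of one another in this assay, so this change separates none of them. No available evidence explains this result. Still open, from the compounds shown here alone, is whether an amine or a carboxylic acid on this carbon would move the number beyond the scatter. Going by these compounds, the effect of a longer chain in place of the neopentyl group also remains open.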